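Replacing a Phenylsulfonyl Group with a Carbamoyl Group

A few compounds are considered here, and "the series" means these few. Any claim that something is new, unique, unknown or untested is made for them only; others in the source may bear on it.

Compound 1 `O=S(=O)(c1ccccc1)N1CCN(c2nccc(Oc3cc(Cl)cc(Cl)c3)n2)CC1` is the starting point here. In a functional assay on MDA-MB-231 cells (Homo sapiens) for antiproliferative activity, read by MTT assay, with a stated time of 24 h (on this read-out lower numbers stand for stronger inhibition and higher numbers for weaker inhibition), compound 1 gives > 50000 nM, which is a limit of the assay and not a number.

Two relatives of compound 1 carry a methoxy on the phenyl ring. Compound 2 `COc1ccccc1S(=O)(=O)N1CCN(c2nccc(Oc3cc(Cl)cc(Cl)c3)n2)CC1`, with 2-methoxyphenyl, gives 16800 nM. Compound 3 `COc1ccc(S(=O)(=O)N2CCN(c3nccc(Oc4cc(Cl)cc(Cl)c4)n3)CC2)cc1`, with 4-methoxyphenyl, gives 46800 nM. The two differ by a 2.8-fold higher number from compound 2 to compound 3 (0.44 log units; beyond the scatter), and the second methoxy placement shows only an at least 1.0-fold lower number from compound 1 to compound 3 (0.02 log units; that floor lies within the scatter).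

Compound 4 `O=C(Nc1cccc(Cl)c1)N1CCN(c2nccc(Oc3cc(Cl)cc(Cl)c3)n2)CC1` keeps the core of compound 1 but changes more: (3-chlorophenyl)carbamoyl in place of phenylsulfonyl on an amine nitrogen in a ring. In words, (3-chlorophenyl)carbamoyl takes the place of phenylsulfonyl on an amine nitrogen in a ring.

For the measured compounds named here, no measured step replaces the sulfonyl link itself, so the evidence is indirect. The step of an at least 2.9-fold lower number from compound 1 to compound 2 (0.47 log units; beyond the scatter) sets the only scale available, and a step of similar, modest size toward a lower number is expected in this assay. The expected change is an at least 2.2-fold lower number from compound 1 to compound 4 (0.35 log units; beyond the scatter). For compound 4 the estimated value is 22000 nM, with an expected range from 8000 nM to 50000 nM.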

Compound 4, half-maximal inhibitory concentration: 7900 nM
The estimate for compound 4 lay 2.8-fold (0.44 log units) above the measured number, and the stated range ends above it.
By their numbers in this assay, from the lowest: compound 4; then compound 2; then compound 3. At a limit, above all of these: compound 1.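

For the compounds shown here, at the amine nitrogen in the ring, the earlier compounds varied only a methoxy on the phenylsulfonyl group, whereas here the whole group changes. In this assay, putting (3-chlorophenyl)carbamoyl in place of phenylsulfonyl gives an at least 6.3-fold lower number from compound 1 to compound 4 (0.80 log units; beyond the scatter), so this position does not need the sulfonyl link to give a measured number, and a group with an amide hydrogen is accepted there. Compound 1 stands at a limit and not at a number, so the true size of this step stays unknown and only its floor can be read: the limit of > 50000 nM in this assay, at which 1 of the 4 values shown sits.

This one step swaps the link and adds a chlorine at the same time, so it remains open which of the two changes accounts for the lower number, and a plain phenylcarbamoyl group and a 3-chlorophenylsulfonyl group would be the pair to separate them. Also open, on these data alone, is how far the position can be pushed, for example with a longer chain such as benzylcarbamoyl, or with an amine or a carboxylic acid on the phenyl ring of the carbamoyl group.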